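A Second Chlorine Added to a Weak Growth Inhibitor

A few compounds are considered here, and "the series" means these few. Any claim that something is new, unique, unknown or untested is made for them only; others in the source may bear on it.

Compound 1, `Cc1ccc(/C=C(/C#N)C(=O)c2ccc[nH]2)cc1`: < 10000 nM (a limit)
Compound 2, `N#C/C(=C/c1ccc(Cl)cc1)C(=O)c1ccc[nH]1`: 31000 nM
Compound 3, `N#C/C(=C/c1ccc(Cl)c(Cl)c1)C(=O)c1ccc[nH]1`: not yet measured

In a functional assay on A-431 cells (Homo sapiens) for cytotoxicity, read by MTT assay, with a stated time of 72 h (a lower number here means a stronger inhibitor of growth, a higher number a weaker inhibitor of growth), compound 1 gives < 10000 nM, which is a limit of the assay and not a number. For the measured compounds named here, compound 2 gives 31000 nM, the only measured number among the values shown. Going by the values given here, the single measured step is an at least 3.1-fold higher number from compound 1 to compound 2 (0.49 log units; beyond the scatter), and its size rests on (the limit of < 10000 nM in this assay, at which 1 of the 2 values shown sits).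

Compound 3 differs from compound 2 by chloro in place of hydrogen on an aromatic carbon. Among the compounds with values here, no measured step exchanges a hydrogen for chloro, so the one step known bears only loosely: it concerns a different exchange at the same ring and gave a weaker inhibitor. With so little to go on, compound 3 is expected to stay close to compound 2, and the step of a 1.2-fold lower number from compound 2 to compound 3 (0.09 log units; within the scatter) is expected to lie within the scatter. For compound 3 the estimated value is 25000 nM, with a range from 8000 nM to 80000 nM.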

Compound 3, concentration for 50% growth inhibition: < 10000 nM
Compound 3 ended at the assay's limit; the forecaster's own chance of this, stated with the estimate: 20%; middle value at least 2.5-fold (0.39 log units) from the limit.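

In this assay, chloro in place of hydrogen on an aromatic carbon, ortho to a chloro group and meta to a large group, gives an at least 3.1-fold lower number from compound 2 to compound 3 (0.49 log units; beyond the scatter). This is the first exchange shown at this position, and it moves the number in the direction opposite to the earlier exchange, an at least 3.1-fold higher number from compound 1 to compound 2 (0.49 log units; beyond the scatter), so among these compounds a new chloro group on the ring does not always go with a weaker inhibitor of growth. The full size of the new step cannot be read, as it rests on a limit: the limit of < 10000 nM in this assay, at which 2 of the 3 values shown sit.

On these data alone, whether the new chloro group would have the same effect without the chloro group already on the ring remains open. Also open, as far as these compounds go, is how an amine, a methoxy group or a carboxylic acid at this position would compare in this assay.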